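Replacing the cyclohexyl group on the piperazine ring

The source may report more compounds than this note shows. Statements on the series, on what has been measured and on what is new or still open speak of the compounds shown alone.

Measured compounds:
Compound 1, `Cc1ccc(Nc2nc(C(F)(F)F)ccc2CNC(=O)C(C)c2ccc(NS(C)(=O)=O)c(F)c2)cc1C`, in a functional assay on CHO-K1 cells for antagonist activity at transient receptor potential cation channel subfamily V member 1 (Homo sapiens), read by FLIPR (a lower number here means a stronger inhibitor, a higher number a weaker inhibitor), gives 39.3 nM.
Compound 2, `CC(C(=O)NCc1ccc(C(F)(F)F)nc1N1CCN(C2CCCCC2)CC1)c1ccc(NS(C)(=O)=O)c(F)c1`, in this assay gives 21.6 nM.

Compound 2 has the lowest of the two numbers, but the step of a 1.8-fold lower number from compound 1 to compound 2 (0.26 log units; within the scatter) is within the scatter, so the two compounds cannot be ordered. Compound 3, `COc1ccc(N2CCN(c3nc(C(F)(F)F)ccc3CNC(=O)C(C)c3ccc(NS(C)(=O)=O)c(F)c3)CC2)cc1`, has not yet been measured. It differs from compound 2 in one place: 4-methoxyphenyl in place of cyclohexyl on an amine nitrogen in a ring. Within the data shown here, no measured step concerns the group on the ring nitrogen; the only step known, from compound 1 to compound 2, exchanges the whole substituent on the aromatic carbon and stays within the scatter. Nothing in the data therefore points to a change beyond the scatter, and the expected step of a 1.2-fold higher number from compound 2 to compound 3 (0.06 log units; within the scatter) is small. Compound 3 is estimated at 25 nM in this assay, with a range from 8 nM to 80 nM.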

Compound 3, inhibition constant: 2.5 nM
Compound 3: middle estimate off by 10-fold (1.00 log units), on the high side, and the stated range ends above it.
By their numbers in this assay, from the lowest: compound 3; then compounds 2 and 1 (each within the scatter of the next).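

In this assay, 4-methoxyphenyl in place of cyclohexyl on the amine nitrogen in the ring gives an 8.6-fold lower number from compound 2 to compound 3 (0.94 log units; beyond the scatter) and so shows that the number responds to the group on this nitrogen. The earlier step, a 1.8-fold lower number from compound 1 to compound 2 (0.26 log units; within the scatter), exchanged the whole substituent on the aromatic carbon and could not show this, whereas here the shared core stays the same and only the group on the nitrogen differs. Nothing available gives a measured reason for this step. The change replaces a non-aromatic carbon ring with an aromatic one and adds an oxygen in the same move, so the compounds shown cannot separate the part played by the aromatic ring from that of the methoxy group. From the compounds shown here alone, whether a plain phenyl group, a 4-chlorophenyl group or a pyridine ring on this nitrogen would give a similar number remains open.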